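Cytotoxicity notes on a diarylpropane series

The source may hold more compounds than are shown below. What is called first, only, known or untested is meant among the compounds shown, and "the series" means these compounds.

Measured so far:
compound 1 `COc1ccc(OC)c(/C=C/C(=O)c2cccc(O)c2)c1`: 99%
compound 2 `COc1ccc(CCCc2cccc(OC)c2OC)c(O)c1`: 99.1%

In an ADME assay on RAW264.7 cells (Mus musculus) for cytotoxicity, read by MTT assay, with a stated time of 24 h, tested at 1.25 ug/mL (on this read-out lower numbers stand for a stronger effect and higher numbers for a weaker effect at the one concentration tested), compound 2 gives 99.1% and compound 1 gives 99%; the two values lie within the scatter of each other, so neither is told apart from the other at this concentration. Compound 3 `COc1ccc(CCCc2ccc(OC)c(OC)c2OC)c(O)c1` is the next member and is not yet tested in this assay. It differs from compound 2 by methoxy in place of hydrogen on an aromatic carbon. Within the data shown here, no step between measured compounds is available to weigh this change, so no shift beyond the scatter is expected in this assay. Compound 3 is expected to give 97%, between 88% and 103%. The step of a number 2.1 percentage points lower from compound 2 to compound 3 (within the scatter) is estimated to sit within the scatter.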

Compound 3, a percentage reported as activity, at one concentration (the size of the read-out at that concentration, not a potency): 96.3%
Estimate against measurement, compound 3: 0.7 percentage points above; measured number inside the range.
By their numbers in this assay, from the lowest: compounds 3, 1 and 2 (each within the scatter of the next).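

In this assay, among these compounds, methoxy in place of hydrogen on this aromatic carbon, ortho to a methoxy group and para to a large group, gives a number 2.8 percentage points lower from compound 2 to compound 3 (within the scatter) and is the first one-place step available. This position therefore takes the added methoxy without a shift that can be told from the scatter. No available evidence bears on this result. Still open, on these data alone, is whether an amine, a carboxylic acid or a longer chain at this position would move the read-out beyond the scatter.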